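This account rests on a few compounds, and the source may have more. Where it says the series, first, only, none or still open, it means among the compounds named here.

Going by the values given here, in an assay on CHO cells for displacement of a labelled ligand from prostaglandin D2 receptor 2 (Homo sapiens), read by scintillation counting (on this read-out higher numbers stand for weaker inhibition and lower numbers for stronger inhibition), compound 1 `CNS(=O)(=O)c1ccc(C)c(C#Cc2cc(Cl)ccc2OCC(=O)O)c1` gives 10 nM, the lower of the two numbers measured so far. Compound 2 `CCCS(=O)(=O)c1cccc(C#Cc2c(Cl)cccc2OCC(=O)O)c1` gives 55 nM in this assay, a number that stands beyond the scatter above compound 1. The two structures differ in several places at once, and nothing more than the two numbers themselves can be read from this pair. Compound 3 `Cc1ccc(S(=O)(=O)CC(C)C)cc1C#Cc1cc(Cl)ccc1OCC(=O)O` has not yet been measured in this assay. It differs from compound 1 in a single place: isobutyl in place of methylamino on a sulfonyl sulfur. Among the compounds with values here, no measured pair isolates this change, so its effect is unknown from the data at hand. The step from compound 1 to compound 3 is expected to be modest, a 2.0-fold higher number from compound 1 to compound 3 (0.30 log units; within the scatter), most likely toward a somewhat higher number. Compound 3 is accordingly estimated at 20 nM in this assay, with a plausible range from 6 nM to 70 nM.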

Compound 3, inhibition constant: 3 nM
Compound 3: middle estimate off by 6.7-fold (0.82 log units), on the high side, outside the stated range (below it).
By their numbers in this assay, from the lowest: compound 3; then compound 1; then compound 2.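

Replacing methylamino with isobutyl on the sulfonyl sulfur gives a 3.3-fold lower number from compound 1 to compound 3 (0.52 log units; beyond the scatter) in this assay and this step lies beyond the usual scatter. The hydrogen-bond donor counted on methylamino, and the nitrogen itself, are therefore not needed for a low number at this place in the core of compound 1, and an all-carbon isobutyl group does better here. No measurement at hand gives a reason for this step.

Going by these compounds, this single swap changes the chain size, the branching and the atom attached to the sulfur all at once, so their separate contributions remain unknown. A straight butyl chain, a dimethylamino group or a cyclopentyl ring on the same sulfur would help to tell them apart.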